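Removing the methoxy group from the thiourea-linked series

The source may hold more compounds than are shown below. What is called first, only, known or untested is meant among the compounds shown, and "the series" means these compounds.

Measured so far:
compound 1 `COc1cccc(NC(=S)N/N=C/c2ccc3ccccc3n2)c1` — 71200 nM
compound 2 `Cc1ccc(NC(=O)N/N=C/c2ccc3ccccc3n2)cc1` — reported only as a limit, > 100000 nM

Going by the values given here, in a functional assay on HL-60 cells (Homo sapiens) for antiproliferative activity, read by sulforhodamine B assay, with a stated time of 72 h (a lower number here means a stronger inhibitor, a higher number a weaker inhibitor), compound 1 gives 71200 nM, the only numerical value in the set. The other entry for compound 2 is a limit of the assay and not a number, so of the two results one sits at the limit of > 100000 nM in this assay, at which 1 of the 2 values shown sits, and nothing can be said about the gap between them beyond that. Compound 1 is therefore the sole anchor.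

Compound 3 `S=C(N/N=C/c1ccc2ccccc2n1)Nc1ccccc1` differs from compound 1 by hydrogen in place of methoxy on an aromatic carbon. Among the compounds with values here, no measured step between compounds exists to calibrate this change. In this assay the expected step of a 1.1-fold higher number from compound 1 to compound 3 (0.05 log units; within the scatter) is none beyond the usual scatter, since the shared core is kept and only a small group is lost. Compound 3 is estimated at 80000 nM, with a range from 30000 nM to 200000 nM, and a real chance that the assay again returns only a limit.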

Compound 3, half-maximal inhibitory concentration: 9130 nM
Compound 3: middle estimate off by 8.8-fold (0.94 log units), on the high side, and the stated range ends above it.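

In this assay, the change from 3-methoxyphenyl to phenyl gives a 7.8-fold lower number from compound 1 to compound 3 (0.89 log units; beyond the scatter) and keeps the shared core, so this place on the aromatic ring is not indifferent to what it carries. Going by these compounds alone, this is the first measured step, where before there was a single number and a limit, and the compound without methoxy is the stronger of the pair. Nothing measured here accounts for the step.

As far as these compounds go, whether another small group at this place, such as fluorine, a hydroxyl or an amine, would behave like hydrogen or like methoxy stays open. Within the data shown here, compound 2 is reported only as a limit and differs from the other compounds in more than one place, so no step to it can be read: the limit of > 100000 nM in this assay, at which 1 of the 3 values shown sits.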